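The source may report more compounds than this note shows. Statements on the series, on what has been measured and on what is new or still open speak of the compounds shown alone.

Compound 1, `Cc1cccc(CSc2cc(Cl)c(C)cc2S(=O)(=O)/N=C(\N)n2nccc2-c2ccccc2)c1`: 0.232 h
Compound 2, `Cc1cc(S(=O)(=O)/N=C(\N)n2nccc2-c2ccccc2)c(SCc2ccc(C(F)(F)F)cc2)cc1Cl`: 0.176 h

Both compounds were tested in an ADME assay on microsomes from liver (Homo sapiens) for metabolic stability, read by LC-MS, using NADPH, tested at 5 uM; on this read-out higher numbers stand for a longer-lived compound and lower numbers for a shorter-lived compound. On the page compound 2 gives the lower of the two numbers, yet the step of a 1.3-fold lower number from compound 1 to compound 2 (0.12 log units; within the scatter) lies within the usual scatter, so the two compounds cannot be told apart on this read-out.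

Compound 3, `Cc1cc(S(=O)(=O)/N=C(\N)n2nccc2-c2ccccc2)c(SCc2cccc3ccccc23)cc1Cl`, has not yet been measured in this assay. It differs from compound 2 in one place: naphthalen-1-yl in place of 4-(trifluoromethyl)phenyl on a saturated chain carbon bound to a sulfur. Within the data shown here, the only measured step that speaks to this change is the one at the same position, where 3-methylphenyl became 4-(trifluoromethyl)phenyl and the number moved by a 1.3-fold lower number from compound 1 to compound 2 (0.12 log units; within the scatter), a change within the scatter. A single step of that size gives little reason to expect a shift beyond the scatter when the group at this place is exchanged once more. The step is therefore expected to read a 1.0-fold higher number from compound 2 to compound 3 (0.01 log units; within the scatter). Compound 3 is estimated at 0.18 h, with a range from 0.09 h to 0.36 h.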

Compound 3, half-life: 0.268 h
Estimate against measurement, compound 3: 1.5-fold (0.17 log units) below, and the stated range covers the measured number.
By their numbers in this assay, from the lowest: compounds 2, 1 and 3 (each within the scatter of the next).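

At the position on a saturated chain carbon bound to a sulfur, naphthalen-1-yl, with its 2 six-membered aromatic rings of carbon only, can now be set against two groups with a single ring. In this assay, the readings are a 1.5-fold higher number from compound 2 to compound 3 (0.18 log units; within the scatter) and a 1.2-fold higher number from compound 1 to compound 3 (0.06 log units; within the scatter). Both steps lie within the usual scatter, so compound 3 cannot be told apart from compound 1 or compound 2 on this read-out, even though the entering group carries a second ring and no fluorine, and no measurement shown here bears on the reason for this result.

From the compounds shown here alone, all three groups at this place are aromatic rings of carbon, so it remains open whether an amine, a carboxylic acid or a longer chain between the sulfur and the ring would give a half-life that stands clear of the scatter. The rest of the structure is the same in compound 1, compound 2 and compound 3, which leaves open what a change elsewhere on the shared core would do to the half-life.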